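From 3-chlorobenzyl to 3-hydroxyphenyl on the shared core

The compounds below may be only part of what the source reports. "The series", "measured", "known", "first", "only" and "open" are said of these compounds alone.

Values so far in a functional assay on MCF7 cells (Homo sapiens) for inhibition, read by fluorescence, with a stated time of 72 h (a lower number here means a stronger inhibitor of growth, a higher number a weaker inhibitor of growth), are these:
- compound 1 `CCCCn1cnc2c(NCc3cccc(Cl)c3)nc(N[C@H]3CC[C@H](N)CC3)nc21` gives 2200 nM
- compound 2 `CC(C)CCn1cnc2c(NCc3cccc(Cl)c3)nc(N[C@H]3CC[C@H](N)CC3)nc21` gives 4700 nM
- compound 3 `CCCCCCn1cnc2c(Nc3cccc(Cl)c3)nc(N[C@H]3CC[C@H](N)CC3)nc21` gives 2700 nM

Compound 2 stands within the scatter of compound 3 and apart from compound 1, with a 2.1-fold higher number from compound 1 to compound 2 (0.33 log units; beyond the scatter) as a modest step on the chain. The change to compound 4 `CC(C)CCn1cnc2c(Nc3cccc(O)c3)nc(N[C@H]3CC[C@H](N)CC3)nc21` is 3-hydroxyphenyl in place of 3-chlorobenzyl on a nitrogen on an aromatic ring and reads 3-hydroxyphenyl in place of 3-chlorobenzyl on a nitrogen on an aromatic ring. Within the data shown here, that chain step is the only one measured and lies elsewhere, so no measured step covers this place. The expected step in this assay is a 1.3-fold lower number from compound 2 to compound 4 (0.13 log units; within the scatter) and lies within the scatter, with no firm direction. For compound 4 the estimated value is 3500 nM with an expected range of 1000 nM to 12000 nM at the upper end.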

Compound 4, concentration for 50% growth inhibition: 12600 nM
The estimate for compound 4 lay 3.6-fold (0.56 log units) below the measured number; measured number outside the range, above it.
By their numbers in this assay, from the lowest: compounds 1, 3 and 2 (each within the scatter of the next, the first and the last beyond it); then compound 4.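

In this assay, among these compounds, 3-hydroxyphenyl in place of 3-chlorobenzyl on a nitrogen on an aromatic ring gives a 2.7-fold higher number from compound 2 to compound 4 (0.43 log units; beyond the scatter), the first measured step at this place and one beyond the scatter. This place therefore responds to substitution, at least for this pair. The step joins two changes, chlorine to hydroxyl and benzyl to phenyl, so it cannot be divided between them. Nothing at hand accounts for the step. Open, as far as these compounds go, is how a 3-hydroxybenzyl group on the same nitrogen, with the chain of compound 2 kept, would read, as that pair would separate the two changes.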